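This account rests on a few compounds, and the source may have more. Where it says the series, first, only, none or still open, it means among the compounds named here.

Measured compounds in an ADME assay on RAW264.7 cells (Mus musculus) for cytotoxicity, read by MTT assay, with a stated time of 48 h; a lower number here means that less compound is tolerated, a higher number that more compound is tolerated:
Compound 1 `CC(=O)OC[C@H]1O[C@H](OC[C@@H](Cn2cc(CN(c3nc(-c4ccc([N+](=O)[O-])cc4)no3)C3CCCCC3)nn2)OC(C)=O)C=C[C@@H]1OC(C)=O`: 64.1 ug/mL
Compound 2 `CC(=O)OC[C@H]1O[C@H](OC[C@H](Cn2cc(-c3ccc(-c4noc(NC5CCCCC5)n4)cc3)nn2)OC(C)=O)C=C[C@@H]1OC(C)=O`: 16.3 ug/mL

In this assay compound 1 gives 64.1 ug/mL. Compound 2 gives 16.3 ug/mL in this assay. Of the two measured numbers, compound 1 holds the higher one, and its gap to compound 2 lies beyond the usual scatter, so more of compound 1 is tolerated than of compound 2. Compound 3 `CC(=O)OC[C@H]1O[C@H](OC[C@@H](Cn2cc(CN(c3nc(-c4ccc(C(F)(F)F)cc4)no3)C3CCCCC3)nn2)OC(C)=O)C=C[C@@H]1OC(C)=O` has not yet been measured in this assay. Against compound 1 it differs at a single place: trifluoromethyl in place of nitro on an aromatic carbon, sitting para to a large group; read one bond further out, 4-nitrophenyl becomes 4-(trifluoromethyl)phenyl. Within the data shown here, no measured pair shows this change by itself, and compound 1 and compound 2 differ in several places at once, so their gap offers no guide to it. The expectation for compound 3 is therefore a step of a 1.2-fold lower number from compound 1 to compound 3 (0.07 log units; within the scatter) that stays within the scatter, with no direction favoured. Compound 3 is estimated at 55 ug/mL in this assay, with a range from 25 ug/mL to 120 ug/mL.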

Compound 3, half-maximal cytotoxic concentration: 64.1 ug/mL
For compound 3 the middle estimate is 1.2-fold (0.07 log units) below the measured one; the range from low to high includes it.
By their numbers in this assay, from the lowest: compound 2; then compounds 1 and 3 (each within the scatter of the next).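

Placing trifluoromethyl in place of nitro on an aromatic carbon, para to a large group, gives no change at the digits printed from compound 1 to compound 3 (within the scatter) in this assay and provides the first reading of this change by itself. At this position, then, the nitro group, with its hydrogen-bond acceptors and its double bond outside aromatic rings, can give way to trifluoromethyl, which has no hydrogen-bond acceptors, without a step beyond the scatter, so neither of those counted features is needed here to hold the number where compound 1 has it. No accompanying measurement bears on why the two groups read alike in these cells.

The compounds shown leave open whether an amine, a carboxylic acid, a methoxy group or a plain hydrogen on that aromatic carbon would also stay within the scatter of compound 1. They also leave open whether the exchange of nitro for trifluoromethyl would read the same way on a compound that differs from compound 1 elsewhere, for instance with a longer chain in place of the cyclohexyl group.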